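Exchanging a urea for a direct phenyl on a ring amine

A few compounds are considered here, and "the series" means these few. Any claim that something is new, unique, unknown or untested is made for them only; others in the source may bear on it.

Of the compounds shown here, two have so far been measured in a functional assay on cells (T-cell, Homo sapiens) for inhibition; on this read-out higher numbers stand for weaker inhibition and lower numbers for stronger inhibition. Compound 1, `CCOc1nc(N)nc2ncc(-c3cccc(OC)c3)nc12`, gives 8300 nM. Compound 2, `COc1ccc(-c2cnc3nc(N)nc(N4CCN(C(=O)Nc5ccccc5)CC4)c3n2)cc1OC`, gives 3.4 nM. Of these two numbers, compound 2 holds the lower one, and the gap between compound 1 and compound 2 lies well beyond the usual scatter of repeated measurements, so compound 2 stands as the more potent of the pair. For the measured compounds named here, no pair of measured compounds differs in a single place, so no isolated structural step has yet been read from the data.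

Compound 3, `COc1ccc(-c2cnc3nc(N)nc(N4CCN(c5ccccc5)CC4)c3n2)cc1OC`, is the next compound to be measured. It differs from compound 2 in one place: phenyl in place of phenylcarbamoyl on an amine nitrogen in a ring. Going by the values given here, with only compound 2 as a reference point, and no measured step of this kind to lean on, the outcome is open. Compound 3 is expected to remain active, and the step of a 5.9-fold higher number from compound 2 to compound 3 (0.77 log units; beyond the scatter) is estimated as a moderate move toward a higher number in this assay. The estimate for compound 3 is 20 nM, with a range from 4 nM to 150 nM.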

Compound 3, half-maximal inhibitory concentration: 400 nM
Compound 3: the middle estimate sits 20-fold (1.30 log units) below what was measured, outside the stated range (above it).
By their numbers in this assay, from the lowest: compound 2; then compound 3; then compound 1.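

In this assay, for the compounds shown here, the step of a 120-fold higher number from compound 2 to compound 3 (2.07 log units; beyond the scatter) gives the first isolated reading at this place, on an amine nitrogen in a ring, and it shows that inhibition in these cells is highly sensitive to what stands there: replacing phenylcarbamoyl with phenyl brings a large move toward weaker inhibition. The six-membered aromatic ring of carbon is present on both sides of the change, so the step cannot be credited to the loss of that ring; what leaves with the phenylcarbamoyl is the urea link, which counts 1 hydrogen-bond donor and 1 hydrogen-bond acceptor, and the entering phenyl has neither. No measurement at hand explains why the step is so large.

Going by these compounds alone, the single step cannot separate the part played by the carbonyl from that of the amide hydrogen, nor from the change in distance between the ring nitrogen and the aromatic ring. As far as these compounds go, a benzoyl group, which keeps the carbonyl but has no amide hydrogen, or a benzyl group, which has a carbon in place of the link, would each bear on these questions, and how either would behave here remains open.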